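Three limit results and a fourth compound still to measure

The compounds below may be only part of what the source reports. "The series", "measured", "known", "first", "only" and "open" are said of these compounds alone.

Compound 1, `Nc1nc(=O)ccn1COCCO`: in a functional assay (Oryctolagus cuniculus) for inhibition (a higher number here means a weaker inhibitor, a lower number a stronger inhibitor), compound 1 gives > 400 ug/mL, a limit of the assay rather than a number.
Compound 2, `OCCOCn1cnc2c(O)ncnc21`: in this assay compound 2 gives > 100 ug/mL, also a limit.
Compound 3, `Nc1nc2c(nc(I)n2COCCO)c(=O)[nH]1`: in this assay compound 3 gives >= 350 ug/mL, again a limit.

Compound 3 therefore stands nowhere definite: its own result is a limit, and the two other results shown are limits as well (the limit of >= 350 ug/mL in this assay, at which 1 of the 3 values shown sits). Compound 4, `CNc1nc2c(=O)[nH]c(N)nc2n1COCCO`, is not yet measured. It differs from compound 3 in one place: methylamino in place of iodo on an aromatic carbon. Among the measured compounds shown here, no step between measured compounds exists, so the size of this change in this assay cannot be read from earlier pairs; the expectation is no step beyond the scatter, most likely another limit. Compound 4 is expected to give about 300 ug/mL, between 60 ug/mL and 1000 ug/mL, an expected step of an at least 1.1-fold lower number from compound 3 to compound 4 (0.06 log units; that floor lies within the scatter).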

Compound 4, concentration for 50% inhibition: > 400 ug/mL
Compound 4 ended at the assay's limit (the forecaster's own chance of this, stated with the estimate: 70%); at least 1.3-fold (0.12 log units) between middle value and limit.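

Among the compounds shown here, compound 3 and compound 4 both gave only limits in this assay, and no step between them can be read. The compounds shown leave open whether iodo or methylamino on this aromatic carbon gives the stronger inhibitor.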